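Triazole substituent variation and HeLa cytotoxicity: notes toward compound 4

The source may report more compounds than this note shows. Statements on the series, on what has been measured and on what is new or still open speak of the compounds shown alone.

Measured so far:
compound 1, `CCCCCCc1cn(C(c2ccccc2)c2cc3cc(Br)ccc3nc2OC)nn1`: -0.97%
compound 2, `CCOC(=O)c1cn(C(c2ccccc2)c2cc3cc(Br)ccc3nc2OC)nn1`: -3.67%
compound 3, `CCCc1cn(C(c2ccccc2)c2cc3cc(Br)ccc3nc2OC)nn1`: -2.25%

All three share one core and differ only in the group on an aromatic carbon of the five-membered aromatic ring with 3 nitrogen. In an ADME assay on HeLa cells (Homo sapiens) for cytotoxicity, read by sulforhodamine B assay, with a stated time of 48 h, tested at 10 uM (a higher number here means more inhibition at the concentration tested (going by the name of the read-out), a lower number less inhibition), compound 3 stands second highest of the three numbers, with a number 1.3 percentage points lower from compound 1 to compound 3 (within the scatter) and a number 1.4 percentage points higher from compound 2 to compound 3 (within the scatter); every listed step lies within the scatter.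

Compound 4, `COc1nc2ccc(Br)cc2cc1C(c1ccccc1)n1cc(-c2ccccc2C(F)(F)F)nn1`, carries 2-(trifluoromethyl)phenyl in place of propyl on an aromatic carbon. Within the data shown here, the steps that bear on this change are those at the same aromatic carbon, a number 2.7 percentage points lower from compound 1 to compound 2 (within the scatter) and a number 1.4 percentage points higher from compound 2 to compound 3 (within the scatter), both small. Therefore no step beyond the scatter is expected in this assay, and the expected step is a number 1.3 percentage points higher from compound 3 to compound 4 (within the scatter). For compound 4 the estimated value is -1%, within -11% to 10%.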

Compound 4, a percentage reported as inhibition, at one concentration (the size of the read-out at that concentration, not a potency): -1.3%
For compound 4 the middle estimate is 0.3 percentage points above the measured one, within the range that was stated.
By their numbers in this assay, from the lowest: compounds 2, 3, 4 and 1 (each within the scatter of the next).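

In this assay an aromatic ring at this carbon reads like the chains and the ester: a number 1 percentage points higher from compound 3 to compound 4 (within the scatter) and a number 0.3 percentage points lower from compound 1 to compound 4 (within the scatter) and a number 2.4 percentage points higher from compound 2 to compound 4 (within the scatter) are the steps. Going from propyl to 2-(trifluoromethyl)phenyl, from 3 to 10 heavy atoms, adds a ring and still gives no step beyond the scatter. Nothing available explains this result.

On these data alone, whether an amine or a carboxylic acid on this carbon would give a step beyond the scatter remains open. Changes to the shared core also remain open.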